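Changing the aryl group while keeping the ring hydroxy

A few compounds are considered here, and "the series" means these few. Any claim that something is new, unique, unknown or untested is made for them only; others in the source may bear on it.

In a functional assay on HT-29 cells (Homo sapiens) for inhibition, read by sulforhodamine B assay, with a stated time of 72 h (a higher number here means a weaker inhibitor, a lower number a stronger inhibitor), compound 2 (`CCSc1ccc(C2C(O)C(=O)N2c2cc(OC)c(OC)c(OC)c2)cc1`) gives 12 nM, level with compound 1 (`COc1ccc(C2C(O)C(=O)N2c2cc(OC)c(OC)c(OC)c2)cc1`) at 12 nM. Together they hold the lowest number of the three measured so far, while compound 3 (`CCSc1ccc(C2CC(=O)N2c2cc(OC)c(OC)c(OC)c2)cc1`) gives 311 nM.

Compound 4 (`COc1ccc(C2C(O)C(=O)N2c2cc(OC)c(OC)c(OC)c2)cc1O`) alters compound 2 in one place, a saturated ring carbon of the four-membered non-aromatic ring, where 3-hydroxy-4-methoxyphenyl replaces 4-(ethylsulfanyl)phenyl: 3-hydroxy-4-methoxyphenyl in place of 4-(ethylsulfanyl)phenyl on a saturated ring carbon.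

Going by the values given here, two measured steps bear on this change. Exchanging methoxy for ethylsulfanyl on the aromatic carbon gave no change at the digits printed from compound 1 to compound 2 (within the scatter), so this one swap on that aromatic ring left the number in place. Removing the hydroxy from the saturated ring carbon gave a 26-fold higher number from compound 2 to compound 3 (1.41 log units; beyond the scatter), a large step, but compound 4 keeps that hydroxy. Among the compounds with values here, compound 4 also carries the methoxy of compound 1, plus an aromatic hydroxy that no measured compound has, so that addition remains untested.

In this assay, the expected result is little or no movement, a 1.2-fold lower number from compound 2 to compound 4 (0.08 log units; within the scatter). The estimated value for compound 4 is 10 nM, within an expected range of 2 nM to 50 nM.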

Compound 4, half-maximal inhibitory concentration: 463 nM
Compound 4: the middle estimate sits 46-fold (1.67 log units) below what was measured; measured number outside the range, above it.
By their numbers in this assay, from the lowest: compounds 1 and 2 (each within the scatter of the next); then compounds 3 and 4 (each within the scatter of the next).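

In this assay the aryl group on the saturated ring carbon proves far less tolerant than the earlier swap suggested: 3-hydroxy-4-methoxyphenyl in place of 4-(ethylsulfanyl)phenyl gives a 39-fold higher number from compound 2 to compound 4 (1.59 log units; beyond the scatter). A single added hydroxy on an aromatic carbon, the only difference in the next comparison, gives a 39-fold higher number from compound 1 to compound 4 (1.59 log units; beyond the scatter), so keeping the hydroxy on the saturated ring carbon is not enough to hold the number low. Nothing available explains this loss of activity.

Going by these compounds, whether the loss is particular to the aromatic hydroxy stays open, and an amine or a fluorine in its place would test that. Also open, on these data alone, is whether the same hydroxy added to the 4-(ethylsulfanyl)phenyl group of compound 2 would cost as much.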